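Fluoro on a Phenyl Ring: Tolerated Dose Outlook

The source may report more compounds than this note shows. Statements on the series, on what has been measured and on what is new or still open speak of the compounds shown alone.

Compound 3 `Cc1nc2c(c(-c3cc(F)c4c(c3C)CCCO4)c1[C@H](OC(C)(C)C)C(=O)O)CN(CCCc1ccccc1)CC2` is one of three compounds tested in an ADME assay on MT2 cells (Homo sapiens) for cytotoxicity, read by XTT assay, with a stated time of 4 days; a higher number here means that more compound is tolerated, a lower number that less compound is tolerated. In this assay compound 3 gives > 40000 nM, which is a limit of the assay and not a measured number. Compound 1 `Cc1ccc(-c2c3c(nc(C)c2[C@H](OC(C)(C)C)C(=O)O)CCN(CCCc2ccccc2)C3)cc1` also gives only the limit > 40000 nM. Compound 2 `Cc1ccc(CCCN2CCc3nc(C)c([C@H](OC(C)(C)C)C(=O)O)c(-c4cc(F)c5c(c4C)CCCO5)c3C2)cc1F` gives the limit > 40000 nM as well. Because (the limit of > 40000 nM in this assay, at which 3 of the 3 values shown sit), the two steps leading to compound 3, a step that the two limits leave unreadable from compound 1 to compound 3 and a step that the two limits leave unreadable from compound 2 to compound 3, cannot be sized. Compound 4 `Cc1nc2c(c(-c3cc(F)c4c(c3C)CCCO4)c1[C@H](OC(C)(C)C)C(=O)O)CN(CCCc1ccccc1F)CC2` differs from compound 3 by fluoro in place of hydrogen on an aromatic carbon. No measured step sizes such a change, so in this assay no step beyond the scatter is expected: a number no higher from compound 3 to compound 4 (the limit leaves the size open). Compound 4 is therefore expected to give about 40000 nM, within a range from 20000 nM to 80000 nM.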

Compound 4, half-maximal cytotoxic concentration: > 40000 nM
Compound 4: only a limit was reported; the forecaster's own chance of this, stated with the estimate: 90%; the middle value lies on the limit itself.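

The steps from compound 2 and compound 3 to compound 4 cannot be read, because each value is a limit of the assay and not a number: the limit of > 40000 nM in this assay, at which 4 of the 4 values shown sit.

The compounds shown leave open where the tolerated concentration of each truly lies, and so whether fluoro in place of hydrogen changes it at all.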